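A few compounds are considered here, and "the series" means these few. Any claim that something is new, unique, unknown or untested is made for them only; others in the source may bear on it.

Working notes on the arylpiperazine propiophenone series, assay of cell viability.

In an ADME assay on Vero cells (Chlorocebus sabaeus) for cytotoxicity, read by resazurin assay, with a stated time of 72 h (on this read-out higher numbers stand for weaker inhibition and lower numbers for stronger inhibition), compound 1 `O=C(CCN1CCN(c2ccc(F)cc2)CC1)c1ccccc1` gives 13400 nM. Compound 2 `O=C(CCN1CCN(c2ccc(C(F)(F)F)cc2)CC1)c1ccccc1`, carrying trifluoromethyl in place of fluoro on an aromatic carbon of the piperazine-linked ring, gives 15700 nM in this assay; the step of a 1.2-fold higher number from compound 1 to compound 2 (0.07 log units; within the scatter) sits inside the scatter, so the two numbers are read as the same. Among the measured compounds shown here, compound 3 `Cc1ccc(C(=O)CCN2CCN(c3ccc(C(F)(F)F)cc3)CC2)cc1`, with methyl in place of hydrogen on an aromatic carbon of the ketone-bearing ring, gives 140000 nM, and the step of an 8.9-fold higher number from compound 2 to compound 3 (0.95 log units; beyond the scatter) is the only change in the set that moves the number beyond the scatter. Compound 1 thus shares its number with compound 2 and stands well apart from compound 3.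

Compound 4 `COc1ccc(C(=O)CCN2CCN(c3ccc(F)cc3)CC2)cc1` is not yet measured. It differs from compound 1 as methoxy in place of hydrogen on an aromatic carbon. The change sits on the same ring, at the same place, as the methyl of compound 3, so the step from compound 2 to compound 3 is the one that bears on it; the step from compound 1 to compound 2 concerns the other ring and does not. A higher number in this assay is therefore expected for compound 4, of a size comparable to the methyl step, given as a 3.7-fold higher number from compound 1 to compound 4 (0.57 log units; beyond the scatter). The estimate for compound 4 is 50000 nM, with a range from 15000 nM to 160000 nM.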

Compound 4, half-maximal inhibitory concentration: 55000 nM
The estimate for compound 4 lay 1.1-fold (0.04 log units) below the measured number, and the stated range covers the measured number.
By their numbers in this assay, from the lowest: compounds 1 and 2 (each within the scatter of the next); then compound 4; then compound 3.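

In this assay, a 4.1-fold higher number from compound 1 to compound 4 (0.61 log units; beyond the scatter) shows that the position para to a large group can take a second group, methoxy, with the same direction of change as methyl, seen in an 8.9-fold higher number from compound 2 to compound 3 (0.95 log units; beyond the scatter). Each step lies beyond the scatter, so across these two pairs the move to a higher number is not tied to methyl alone, nor to trifluoromethyl on the other ring, since compound 4 keeps the fluoro of compound 1; neither pair goes against this, though two pairs are a narrow base. No available evidence bears on why this position responds in this way.

The compounds shown leave open whether an amine, a carboxylic acid or a longer alkoxy chain at this same position would also give a higher number, and whether a halogen such as chloro would do so. They also leave open how methoxy behaves with trifluoromethyl on the other ring, so the effect of methoxy is known against the fluoro background only.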